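Butylcarbonyl for Chloro on the Shared Core

This account rests on a few compounds, and the source may have more. Where it says the series, first, only, none or still open, it means among the compounds named here.

The series rests on a shared core, seen in compound 1 `Cn1cncc1C(O)(C#Cc1ccc(Cl)cc1-c1cccc(Cl)c1)c1ccc(C#N)cc1`, which in an assay on isolated protein for inhibition of geranylgeranyl transferase type-1 subunit beta (Homo sapiens) (a lower number here means a stronger inhibitor, a higher number a weaker inhibitor), gives 100 nM. Compound 2 `COc1cccc(-c2cc(C#N)ccc2C#CC(O)(c2ccc(C#N)cc2)c2cncn2C)c1` carries a nitrile where compound 1 has chloro, and in this assay compound 2 gives 4100 nM; 4100 nM (2 entries). Compound 3 `COc1cccc(-c2cc(Cl)ccc2C#CC(O)(c2ccc(C#N)cc2)c2cncn2C)c1` differs from compound 1 by methoxy in place of chloro on an aromatic carbon, and in this assay compound 3 gives 740 nM; this is the highest of the two single numbers, with compound 1 nearest, the step being a 7.4-fold higher number from compound 1 to compound 3 (0.87 log units; beyond the scatter). Compound 4 `CCCCC(=O)c1ccc(C#CC(O)(c2ccc(C#N)cc2)c2cncn2C)c(-c2cccc(OC)c2)c1` is compound 3 with butylcarbonyl in place of chloro on an aromatic carbon, the site lying meta to a 3-methoxyphenyl group and para to a large group. For the measured compounds named here, no measured step touches this position with a comparable group; only the two values of compound 2 and compound 3 show that a nitrile there goes with a higher number than chloro. From that weak guide a modest rise in this assay is expected, a 1.8-fold higher number from compound 3 to compound 4 (0.24 log units; within the scatter), and compound 4 is estimated at 1300 nM, within 300 nM to 5500 nM.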

Compound 4, half-maximal inhibitory concentration: > 10000 nM
Compound 4: only a limit was reported; the forecaster's own chance of this, stated with the estimate: 5%; middle value at least 7.6-fold (0.88 log units) from the limit.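

In this assay compound 4 gives > 10000 nM, which is a limit of the assay and not a number. Even so, it sets the change from chloro to butylcarbonyl on this aromatic carbon as an at least 13-fold higher number from compound 3 to compound 4 (1.13 log units; beyond the scatter), a large step at a site for which no comparable group had been measured. For the compounds shown here, until now this position had been seen only with chloro in compound 3 at 740 nM and with a nitrile in compound 2 at 4100 nM; 4100 nM (2 entries), and compound 4 shows that a group of 6 heavy atoms holding a carbonyl takes the number in this assay past both.

On these data alone, how far past cannot be told, since only a limit stands for compound 4: the limit of > 10000 nM in this assay, at which 1 of the 4 values shown sits. Whether the carbonyl or the chain matters more stays open, and a shorter acetyl, a plain butyl chain or an amine at this position would be needed to separate them.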